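The source may hold more compounds than are shown below. What is called first, only, known or untested is meant among the compounds shown, and "the series" means these compounds.

Measured so far in a functional assay on CHO cells for agonist activity at Free fatty acid receptor 2 (Homo sapiens), read by cAMP accumulation; on this read-out lower numbers stand for stronger inhibition and higher numbers for weaker inhibition:
compound 1 `CC(C)[C@H](C(=O)Nc1ccc(F)cn1)c1ccc(Cl)cc1` — 1300 nM
compound 2 `CC(C)C(C(=O)Nc1cnccn1)c1ccc(Cl)cc1` — 5700 nM
compound 3 `CC(C)C(C(=O)Nc1nnn[nH]1)c1ccc(Cl)cc1` — 100000 nM

Compound 1 stands lowest of the three numbers in this assay; compound 2 is its nearest neighbour, compound 3 lies furthest away. Compound 4 `CC(C)[C@H](C(=O)NC1=NC(=O)CS1)c1ccc(Cl)cc1` is not yet measured. Its change from compound 1 is a group of 6 heavy atoms (3 carbon, 1 nitrogen, 1 oxygen, 1 sulfur; one five-membered non-aromatic ring with 2 hetero atoms) in place of a group of 7 heavy atoms (5 carbon, 1 nitrogen, 1 fluorine; one six-membered aromatic ring with 1 hetero atom), on an amide-type nitrogen. Within the data shown here, the one measured step that touches the same position is an 18-fold higher number from compound 2 to compound 3 (1.24 log units; beyond the scatter), in which a six-membered aromatic group on the amide nitrogen was exchanged for a five-membered one, with a large loss. Compound 4 likewise trades a six-membered aromatic ring for a five-membered ring, so a higher number, beyond the scatter, is expected, amounting to a 12-fold higher number from compound 1 to compound 4 (1.06 log units; beyond the scatter). The estimate for compound 4 is 15000 nM, within a range of 3000 nM to 80000 nM.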

Compound 4, half-maximal inhibitory concentration: 20000 nM
Compound 4: the middle estimate sits 1.3-fold (0.12 log units) below what was measured; the range from low to high includes it.
By their numbers in this assay, from the lowest: compound 1; then compound 2; then compound 4; then compound 3.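

In this assay, the five-membered non-aromatic ring on the amide-type nitrogen gives a 15-fold higher number from compound 1 to compound 4 (1.19 log units; beyond the scatter). A large rise at this position is therefore not confined to the 1H-tetrazol-5-yl exchange, an 18-fold higher number from compound 2 to compound 3 (1.24 log units; beyond the scatter), and also occurs when the incoming ring is non-aromatic. No supporting data bear on the origin of this rise.

This single change alters ring size, aromaticity and hetero atoms together, so their contributions remain inseparable. A thiazol-2-yl ring or a plain phenyl ring on this nitrogen would help to separate them.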